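Ester variation on a shared core: toward compound 3

This account rests on a few compounds, and the source may have more. Where it says the series, first, only, none or still open, it means among the compounds named here.

Compound 1 `C=C1C(=O)O[C@H]2CC3=C[C@H](C/C(C)=C/[C@@H](OC(=O)c4ccc([N+](=O)[O-])cc4)[C@H]12)OC3=O` and compound 2 `C=C1C(=O)O[C@H]2CC3=C[C@H](C/C(C)=C/[C@@H](OC(=O)c4ccc(C(C)=O)cc4)[C@H]12)OC3=O` share one core and differ only in the aromatic ester. In a functional assay on NCI-H460 cells (Homo sapiens) for cytotoxicity, read by MTT assay, with a stated time of 48 h (a higher number here means a weaker inhibitor, a lower number a stronger inhibitor), compound 1 reaches only a limit, > 10000 nM, which is the limit of > 10000 nM in this assay, at which 1 of the 2 values shown sits. Going by the values given here, compound 2 gives 2200 nM in this assay, the only number measured so far, with an at least 4.5-fold lower number from compound 1 to compound 2 (0.65 log units; beyond the scatter). Compound 3 `C=C1C(=O)O[C@H]2CC3=C[C@H](C/C(C)=C/[C@@H](OC(=O)CC4CCCCC4)[C@H]12)OC3=O` carries cyclohexylmethyl in place of 4-acetylphenyl on a carbonyl carbon. Among the compounds with values here, the single measured step, acetyl in place of nitro on an aromatic carbon, does not bear on trading an aromatic ester for a non-aromatic one. A step of a 1.4-fold higher number from compound 2 to compound 3 (0.13 log units; within the scatter) is expected, within the scatter. Compound 3 is estimated at 3000 nM, with a range from 1000 nM to 9000 nM.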

Compound 3, half-maximal inhibitory concentration: 2000 nM
Compound 3: middle estimate off by 1.5-fold (0.18 log units), on the high side, and the stated range covers the measured number.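

At this position on the carbonyl carbon, an aromatic ring is not needed to hold activity in this assay: cyclohexylmethyl in place of 4-acetylphenyl gives a 1.1-fold lower number from compound 2 to compound 3 (0.04 log units; within the scatter) and leaves the level unchanged. In place of 4-nitrophenyl, the same group gives an at least 5.0-fold lower number from compound 1 to compound 3 (0.69 log units; beyond the scatter) and sets compound 1 apart from both other esters. Compound 1 stands only as a limit: the limit of > 10000 nM in this assay, at which 1 of the 3 values shown sits.

Open, from the compounds shown here alone, is whether the ring is needed at all, as a longer straight carbon chain would show. Also open, going by these compounds, is how an amine or a carboxylic acid on the ester group would read.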